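Urea to Amide: From Compound 3 to Compound 4

The source may hold more compounds than are shown below. What is called first, only, known or untested is meant among the compounds shown, and "the series" means these compounds.

Compound 3 `COc1cc(Cl)cc(-c2nn(-c3cccc(NC(=O)Nc4ccc(Cl)c(Cl)c4)c3)cc2-c2ccncc2)c1` gives 100% in a functional assay on M14 cells (Homo sapiens) for inhibition, read by sulforhodamine B assay, with a stated time of 48 h, tested at 0.1 uM (a lower number here means a stronger effect, a higher number a weaker effect of the compound at the concentration tested), the highest of three numbers. Compound 1 `O=C(Nc1cccc(-n2cc(-c3ccncc3)c(-c3cc(O)cc(Cl)c3)n2)c1)Nc1ccc(Cl)c(Cl)c1` gives 93% and compound 2 `COc1cc(Cl)cc(-c2nn(-c3cccc(NC(=O)Nc4cc(C(F)(F)F)cc(C(F)(F)F)c4)c3)cc2-c2ccncc2)c1` gives 93%; both gaps to compound 3 lie within the scatter. Going by the values given here, the only single-point step, a number 7 percentage points higher from compound 1 to compound 3 (within the scatter), is likewise within the scatter.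

Compound 4 `COc1cc(Cl)cc(-c2nn(-c3cccc(NC(=O)c4cccc(C(F)(F)F)c4)c3)cc2-c2ccncc2)c1` differs from compound 3 by 3-(trifluoromethyl)phenyl in place of (3,4-dichlorophenyl)amino on a carbonyl carbon. Among the compounds with values here, no measured step bears on this change; the three values simply agree with each other. Compound 4 is therefore expected to show a number 5 percentage points lower from compound 3 to compound 4 (within the scatter), nothing beyond the scatter in either direction. The estimate for compound 4 is 95%, with a range from 80% to 105%.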

Compound 4, a percentage reported as activity, at one concentration (the size of the read-out at that concentration, not a potency): 93%
Compound 4: the middle estimate sits 2 percentage points above what was measured; measured number inside the range.
By their numbers in this assay, from the lowest: compounds 1, 2, 4 and 3 (each within the scatter of the next).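

In this assay, replacing (3,4-dichlorophenyl)amino with 3-(trifluoromethyl)phenyl on the carbonyl carbon gives a number 7 percentage points lower from compound 3 to compound 4 (within the scatter). This first step at this position shows that a change from the urea of compound 3 to the amide of compound 4, with the aryl ring attached directly to the carbonyl carbon, does not move the read-out beyond the scatter. No available evidence explains this result. The compounds shown leave open whether any group on this carbonyl carbon can move the read-out beyond the scatter. As far as these compounds go, a longer alkyl chain or an amine there remains untested in this account.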